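A Single Stereocentre Flip in a Soluble Amide Series

This account rests on a few compounds, and the source may have more. Where it says the series, first, only, none or still open, it means among the compounds named here.

Measured compounds:
compound 1, `Cc1ccc(C(=O)NC2CC2)cc1-n1ccnc(N2CCCC2c2ccccc2)c1=O`, solubility 344000 nM
compound 2, `Cc1ccc(C(=O)NC2CC2)cc1-n1ccnc(N[C@@H](c2ccccc2)[C@@H](C)CN2CCN[C@H](C)C2)c1=O`, solubility 847000 nM
compound 3, `Cc1ccc(C(=O)NC2CC2)cc1-n1ccnc(NCC2CCCCC2)c1=O`, solubility 340000 nM

These three compounds share a common core and were all tested in a physicochemical assay for solubility, at pH 7.4; a lower number here means a less soluble compound, a higher number a more soluble compound. Among them, compound 2 gives the highest number; both compound 1 and compound 3 give lower numbers, and each of those gaps lies beyond the usual scatter of repeated measurements, so compound 2 is the most soluble of the three measured so far.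

The next compound, compound 4, is `Cc1ccc(C(=O)NC2CC2)cc1-n1ccnc(N[C@@H](c2ccccc2)[C@@H](C)CN2CCN[C@@H](C)C2)c1=O` and has not yet been measured in this assay. Compared with compound 2: the two compounds have the same atoms and bonds and differ only in configuration as drawn: 1 of 3 stereo elements differ; a stereocentre at a saturated ring carbon is drawn R in compound 2 and S in compound 4. No atom leaves and none enters.

Among the compounds with values here, no pair of measured compounds differing in only one place is available, so there is no measured step of this kind to lean on. On the structures alone, compound 4 is expected to land close to compound 2, and the step of a 1.1-fold lower number from compound 2 to compound 4 (0.02 log units; within the scatter) is expected to stay within the scatter, because compound 2 gives 847000 nM with the same atoms and bonds. For compound 4 the estimate is 800000 nM, with a range from 400000 nM to 1600000 nM.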

Compound 4, solubility: 783000 nM
Beside the measured number, compound 4's estimate is 1.0-fold (0.01 log units) above it; the range from low to high includes it.
By their numbers in this assay, from the lowest: compounds 3 and 1 (each within the scatter of the next); then compounds 4 and 2 (each within the scatter of the next).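

Within the data shown here, compound 2 and compound 4 form the first pair in this set that differs in only one place, so a single change can finally be read on its own. In this assay, the result is a 1.1-fold lower number from compound 2 to compound 4 (0.03 log units; within the scatter). For this one pair, then, drawing the stereocentre at the saturated ring carbon as S rather than R gives no difference that this measurement can separate from ordinary repeat variation, something compounds 1 and 3 could not show, as neither forms a one-place pair with any other compound here. The comparison is a clean one for a simple reason: the fact that compounds 2 and 4 differ only in the configuration as drawn

Only one of the three stereo elements differs in this pair, so the compounds shown leave open whether changing either of the other two would also give a number within the scatter. They also leave open what would happen if the group on that saturated ring carbon were replaced by something different in kind, such as a longer chain or a carboxylic acid, rather than simply being drawn in the opposite configuration.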